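The source may report more compounds than this note shows. Statements on the series, on what has been measured and on what is new or still open speak of the compounds shown alone.

Compound 1 `CCCCOc1ccc(C(=O)NNc2c(Br)cccc2Br)cc1` was tested in a toxicity assay on MDCK cells (Canis lupus familiaris) for cytotoxicity, read by CCK-8 assay, with a stated time of 48 h (on this read-out lower numbers stand for higher toxicity in this test and higher numbers for lower toxicity in this test), and gave only a limit, > 100000 nM, not a number. Compound 2 `CCCc1ccc(C(=O)NNc2c(Cl)cccc2Cl)cc1` likewise gave only a limit in this assay, > 100000 nM. Both results therefore sit at the limit of > 100000 nM in this assay, at which 2 of the 2 values shown sit. Compound 3 `O=C(O)c1ccc(C(=O)NNc2c(Br)cccc2Br)cc1` has not yet been measured; compared with compound 1 it differs by carboxy in place of butoxy on an aromatic carbon, the butoxy leaving and a carboxy entering on an aromatic carbon. For the measured compounds named here, no measured step between compounds is available to guide the expectation. The step from compound 1 to compound 3 is expected to be a step that the limit leaves unreadable from compound 1 to compound 3, with nothing beyond the scatter foreseen. Compound 3 is estimated at 150000 nM, in a range from 60000 nM to 400000 nM.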

Compound 3, half-maximal cytotoxic concentration: > 100000 nM
Compound 3: only a limit was reported; the forecaster's own chance of this, stated with the estimate: 85%; the middle value is on the limit's open side.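

Compound 1 and compound 3 both gave only a limit, not a number, so no step between them can be read: the limit of > 100000 nM in this assay, at which 3 of the 3 values shown sit.

The compounds shown leave open what concentration, if any, harms these cells, and whether carboxy in place of butoxy changes it.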